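Cyclopropyl in place of but-1-yn-1-yl on the shared core

This account rests on a few compounds, and the source may have more. Where it says the series, first, only, none or still open, it means among the compounds named here.

compound 1 `CCC#C[C@@]1(O)[C@@H](CO)O[C@@H](n2ccc(N)nc2=O)[C@@H]1O`: 108000 nM
compound 2 `CCC[C@@]1(O)[C@@H](CO)O[C@@H](n2ccc(=O)[nH]c2=O)[C@@H]1O`: > 350000 nM
compound 3 `C#C[C@]1(O)[C@@H](CO)O[C@@H](n2ccc(=O)[nH]c2=O)[C@@H]1O`: > 350000 nM; 29 nM (2 entries)

Among the measured compounds shown here, in a functional assay on KB cells (Homo sapiens), read by MTT assay (on this read-out higher numbers stand for weaker inhibition and lower numbers for stronger inhibition), compound 1 gives 108000 nM, the only plain number in this set. For compound 2 the result > 350000 nM is a limit of the assay and not a number. Compound 3 carries two entries, (the several entries of compound 3 in this assay, > 350000 nM; 29 nM (2 entries)), one of them a limit and the other a number, so no single value stands for it. For the measured compounds named here, compound 1 therefore is the one compound here with a single measured number, and nothing can be ranked against it. Going by the values given here, no step between measured compounds that differ in one place is available.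

Compound 4 `Nc1ccn([C@@H]2O[C@H](CO)[C@](O)(C3CC3)[C@H]2O)c(=O)n1` differs from compound 1 by cyclopropyl in place of but-1-yn-1-yl on a saturated ring carbon. Among the compounds with values here, with no measured step to lean on, the move from compound 1 to compound 4 is expected to stay within the scatter, with a broad range to either side. Compound 4 is expected to give 150000 nM in this assay, between 40000 nM and 500000 nM. The step of a 1.4-fold higher number from compound 1 to compound 4 (0.14 log units; within the scatter) is expected to be no more than the scatter.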

Compound 4, half-maximal inhibitory concentration: > 350000 nM
Compound 4: no number, only a limit (the forecaster's own chance of this, stated with the estimate: 35%); at least 2.3-fold (0.36 log units) between middle value and limit.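

In this assay compound 4 gives > 350000 nM, which is a limit of the assay and not a number. Cyclopropyl in place of but-1-yn-1-yl on the saturated ring carbon gives an at least 3.2-fold higher number from compound 1 to compound 4 (0.51 log units; beyond the scatter), the only measured step at this position, so the number here does respond to the group carried. The size of this step is open at its upper end because the result for compound 4 is a limit: the limit of > 350000 nM in this assay, at which 2 of the 4 values shown sit.

The compounds shown leave open whether an amine or a longer chain on this ring carbon would give a lower number than compound 1 does. Compound 2 and compound 3 differ from compound 1 in more than one place and add no readable step, and the result for compound 3 stays unsettled: the several entries of compound 3 in this assay, > 350000 nM; 29 nM (2 entries)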